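Methoxy entering ortho to hydroxy: expected step in series

This account rests on a few compounds, and the source may have more. Where it says the series, first, only, none or still open, it means among the compounds named here.

Compound 1 `COc1ccc(/C=C/C(=O)c2ccccc2-c2ccc(F)cc2)cc1` gives 93 nM in a functional assay on HepG2 cells (Homo sapiens) for antiproliferative activity, read by sulforhodamine B assay, with a stated time of 48 h; on this read-out higher numbers stand for weaker inhibition and lower numbers for stronger inhibition. Compound 2 `COc1ccc(/C=C/C(=O)c2ccccc2-c2ccc(F)cc2)cc1OC` gives 95 nM in this assay. The change between them, (methoxy in place of hydrogen on an aromatic carbon), made a step of a 1.0-fold higher number from compound 1 to compound 2 (0.01 log units; within the scatter). Compound 3 `O=C(/C=C/c1ccccc1-c1ccc(F)cc1)c1cccc(O)c1` gives 4200 nM in this assay; the difference between its core and the core of compound 1 is not broken down here. Compound 4 `COc1ccc(C(=O)/C=C/c2ccccc2-c2ccc(F)cc2)cc1O` differs from compound 3 by methoxy in place of hydrogen on an aromatic carbon. The surroundings differ: in compound 2 the entering methoxy sits ortho to a methoxy group and meta to a large group, in compound 4 ortho to a hydroxy group and para to a large group, so this is the same kind of change, not the same change. The step from compound 3 to compound 4 is expected to be a 1.2-fold lower number from compound 3 to compound 4 (0.08 log units; within the scatter), resting on a 1.0-fold higher number from compound 1 to compound 2 (0.01 log units; within the scatter). Compound 4 is therefore expected at 3500 nM, between 1200 nM and 10000 nM.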

Compound 4, half-maximal inhibitory concentration: 190 nM
Beside the measured number, compound 4's estimate is 18-fold (1.27 log units) above it; the measured number lies below the stated range.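

Methoxy entering ortho to a hydroxy group gives a 22-fold lower number from compound 3 to compound 4 (1.34 log units; beyond the scatter) in this assay. The same change does not carry over at the same size from one core to the other: the same change on two cores in this assay, a 1.0-fold higher number (0.01 log units; within the scatter) from compound 1 to compound 2 and a 22-fold lower number (1.34 log units; beyond the scatter) from compound 3 to compound 4, 23-fold (1.35 log units) apart, beyond the scatter of two such steps This shows that a step measured on the core of compound 1 does not predict the step on the core of compound 3, but not what sets the gap, as the two steps differ in core and in surroundings at once and the data do not separate these.

Open, going by these compounds, is whether the step of this size appears on the core of compound 3 without the hydroxy group. Also open, on these data alone, is whether an ethoxy group or an amine in place of the methoxy gives a similar step.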